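This account rests on a few compounds, and the source may have more. Where it says the series, first, only, none or still open, it means among the compounds named here.

Measured compounds:
- compound 1, `Cc1cccc(C)c1-c1cccc(COc2ccc3c(c2)OCC3CC(=O)O)c1`: 27 nM
- compound 2, `Cc1cccc(C)c1-c1cccc(COc2ccc3c(ccn3CC(=O)O)c2)c1`: "not determined" (no result reported)
- compound 3, `O=C(O)CC1COc2cc(OCc3cccc(-c4csc5ccccc45)c3)ccc21`: 39 nM

In a functional assay on CHO cells for agonist activity at Free fatty acid receptor 1 (Homo sapiens), read by FLIPR, with a stated time of 90 s, in the presence of a further agent that is not named here (on this read-out lower numbers stand for an effect already at smaller amounts and higher numbers for an effect only at larger amounts of compound), compound 1 gives 27 nM and compound 3 gives 39 nM. Among the compounds with values here, compound 2 has no number in this assay, so only two values carry weight. Within the data shown here, compound 3 holds the higher of the two numbers, but the single step that connects them, a 1.4-fold higher number from compound 1 to compound 3 (0.16 log units; within the scatter), falls within the scatter, so the two compounds are not separated on this read-out.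

Compound 4, `Cc1ccc(-c2cccc(COc3ccc4c(c3)OCC4CC(=O)O)c2)c(C)c1`, has not yet been measured. Its change from compound 3 is 2,4-dimethylphenyl in place of 1-benzothiophen-3-yl on an aromatic carbon. Among the measured compounds shown here, the only step that bears on this is the one in which the same 1-benzothiophen-3-yl replaced a dimethylphenyl group: a 1.4-fold higher number from compound 1 to compound 3 (0.16 log units; within the scatter), within the scatter. The present change returns to a dimethylphenyl group, now the 2,4-dimethylphenyl, on the shared core. For the measured compounds named here, with one comparison of that kind and no separation beyond the scatter, no step of any size beyond the scatter is expected in this assay for compound 4.

Compound 4 is therefore estimated at 35 nM in this assay, within a range of 12 nM to 110 nM, which means an expected step of a 1.1-fold lower number from compound 3 to compound 4 (0.05 log units; within the scatter) from compound 3.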

Compound 4, half-maximal effective concentration in the Free fatty acid receptor 1 assay: 29 nM
Compound 4: middle estimate off by 1.2-fold (0.08 log units), on the high side; the range from low to high includes it.
By their numbers in the Free fatty acid receptor 1 assay, from the lowest: compounds 1, 4 and 3 (each within the scatter of the next).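

In the Free fatty acid receptor 1 assay compound 4 gives 29 nM and 2,4-dimethylphenyl in place of 1-benzothiophen-3-yl gives a 1.3-fold lower number from compound 3 to compound 4 (0.13 log units; within the scatter), and 2,4-dimethylphenyl in place of 2,6-dimethylphenyl gives a 1.1-fold higher number from compound 1 to compound 4 (0.03 log units; within the scatter), so all three groups at this place, on an aromatic carbon meta to a large group, now stand unseparated on the shared core, and the two arrangements of the methyl groups on the phenyl ring are not told apart by this read-out. In a physicochemical assay for lipophilicity, measured as octanol-water partition, at pH 7.4 (on this read-out higher numbers stand for higher lipophilicity and lower numbers for lower lipophilicity), compound 3 gives 3.99 and compound 4 gives 4.15 and the change from 1-benzothiophen-3-yl to 2,4-dimethylphenyl gives a number 0.16 log units higher from compound 3 to compound 4 (within the scatter), so this exchange separates the pair on neither read-out. Nothing available here bears on why these groups are not separated.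

All groups shown at this place are aromatic and uncharged, so it remains open whether a phenyl ring carrying an amine or a hydroxyl group, or an open alkyl chain in place of the ring, would stay in the same range. The carboxylic acid is also common to compounds 1, 3 and 4, which leaves open what an amide or a tetrazole at that end of the molecule would do.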